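A few compounds are considered here, and "the series" means these few. Any claim that something is new, unique, unknown or untested is made for them only; others in the source may bear on it.

Measured so far in a functional assay on MKN-45 cells (Homo sapiens) for cytotoxicity, read by MTT assay, with a stated time of 72 h; a higher number here means a weaker inhibitor, a lower number a stronger inhibitor:
- compound 1 `CN(C)CCn1cnnc1-c1cc(Oc2ccc(NC(=O)N/N=C/c3c(Cl)cccc3Cl)cc2F)ccn1` gives 160 nM
- compound 2 `COc1ccc(/C=N/NC(=O)Nc2ccc(Oc3ccnc(-c4nncn4CCN(C)C)c3)c(F)c2)c(OC)c1` gives 1680 nM

Among the measured compounds shown here, compound 2 stands at the highest of the two numbers so far; its nearest neighbour is compound 1, separated from it by an 11-fold higher number from compound 1 to compound 2 (1.02 log units; beyond the scatter). That step changed only the aryl group on the carbon with a double bond to nitrogen, and it is the single piece of structure–activity information available here.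

Compound 3 `CN(C)CCn1cnnc1-c1cc(Oc2ccc(NC(=O)N/N=C/c3ccc(O)cc3)cc2F)ccn1` has not yet been measured. Its change relative to compound 2 is 4-hydroxyphenyl in place of 2,4-dimethoxyphenyl on a carbon with a double bond to nitrogen. For the measured compounds named here, only the step from compound 1 to compound 2 bears on this position, and it was large, so the aryl group on this carbon clearly matters; however, neither measured compound carries a 4-hydroxyphenyl, so the direction for compound 3 cannot be read off directly. Compound 3 is expected to land somewhere between the two measured numbers, giving an expected step of a 2.4-fold lower number from compound 2 to compound 3 (0.38 log units; beyond the scatter). The estimate for compound 3 in this assay is 700 nM, with a range from 200 nM to 2500 nM.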

Compound 3, half-maximal inhibitory concentration: 820 nM
Compound 3: middle estimate off by 1.2-fold (0.07 log units), on the low side; the measured number falls inside the stated range.
By their numbers in this assay, from the lowest: compound 1; then compound 3; then compound 2.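

The third aryl group turns a single contrast at this position into a small series in this assay: a 2.0-fold lower number from compound 2 to compound 3 (0.31 log units; beyond the scatter), while a 5.1-fold higher number from compound 1 to compound 3 (0.71 log units; beyond the scatter). The 4-hydroxyphenyl group, with 7 heavy atoms, 1 hydrogen-bond donor and 1 hydrogen-bond acceptor, therefore gives a lower number than the 2,4-dimethoxyphenyl group, with 10 heavy atoms, 0 hydrogen-bond donors and 2 hydrogen-bond acceptors, but it does not reach the number given by the 2,6-dichlorophenyl group, so among these three compounds the two oxygen-bearing aryl groups both stand above the dichlorinated one. No measurement is available that explains this order, which remains an observation on these three compounds alone.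

The step from the 2,4-dimethoxyphenyl group to the 4-hydroxyphenyl group changes the substituents and their number together, so the compounds shown cannot separate the effect of the hydroxyl group from the loss of a methoxy group. An unsubstituted phenyl ring, a phenyl ring carrying a single methoxy group or a single chlorine atom, or one carrying an amine would be needed to tell which feature of these aryl groups tracks the numbers in this assay.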